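The compounds below may be only part of what the source reports. "The series", "measured", "known", "first", "only" and "open" are said of these compounds alone.

Measured so far:
- compound 1, `CCOC(=O)c1c(N)sc(-c2ccc(C(C)=O)cc2)c1-c1cccc(C(F)(F)F)c1`, 64.6%
- compound 2, `CCOC(=O)c1c(N)sc(-c2ccc(Cl)cc2)c1-c1cccc(C(F)(F)F)c1`, 58.4%
- compound 3, `CCOC(=O)c1c(N)sc(-c2ccc(OC)cc2)c1-c1cccc(C(F)(F)F)c1`, 81.5%

All three share one core and differ only in the group on the outer aromatic ring. In an assay on CHO-K1 cells for displacement of a labelled ligand from adenosine receptor A1 (Homo sapiens), tested at 10 uM (a lower number here means less inhibition, a higher number more inhibition at the concentration tested (going by the name of the read-out)), compound 3 gives the highest of the three numbers: a number 16.9 percentage points higher from compound 1 to compound 3 (beyond the scatter) and a number 23.1 percentage points higher from compound 2 to compound 3 (beyond the scatter) both lie beyond the scatter, while a number 6.2 percentage points lower from compound 1 to compound 2 (within the scatter) does not.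

Compound 4, `CCOC(=O)c1c(N)sc(-c2ccc(-c3ccncc3)cc2)c1-c1cccc(C(F)(F)F)c1`, has not yet been measured in this assay. It differs from compound 3 by pyridin-4-yl in place of methoxy on an aromatic carbon. The two steps that bear on this change, a number 16.9 percentage points higher from compound 1 to compound 3 (beyond the scatter) and a number 23.1 percentage points higher from compound 2 to compound 3 (beyond the scatter), show that exchanging the group at this position moves the inhibition modestly, and that methoxy gave the highest number among the three. Among the measured compounds shown here, no measured step joins methoxy to a pyridin-4-yl or any other ring, so the direction for compound 4 is uncertain; since compound 3 already stands highest, a step downward, of about the size seen between the measured compounds, is the expected outcome. Compound 4 is therefore estimated at 65%, within 35% to 88%, meaning an expected step of a number 16.5 percentage points lower from compound 3 to compound 4 (beyond the scatter).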

Compound 4, a percentage reported as inhibition, at one concentration (the size of the read-out at that concentration, not a potency): 91%
Compound 4: middle estimate off by 26 percentage points, on the low side; measured number above the stated range.
By their numbers in this assay, from the lowest: compounds 2 and 1 (each within the scatter of the next); then compounds 3 and 4 (each within the scatter of the next).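

In this assay, this position accepts a whole pyridin-4-yl ring in place of the much smaller methoxy with no change beyond the scatter: a number 9.5 percentage points higher from compound 3 to compound 4 (within the scatter). The ring also stands clear of the two other groups, with a number 32.6 percentage points higher from compound 2 to compound 4 (beyond the scatter) and a number 26.4 percentage points higher from compound 1 to compound 4 (beyond the scatter), and the step from chloro is the only large one shown at this position. The top of the series is thus shared by two groups, one with a ring and one without, so a ring here is no drawback in this single-concentration read-out. Nothing shown explains this result. Going by these compounds, it remains open whether the ring nitrogen matters, which a plain phenyl ring would test, and whether a piperidine ring or an amine at this position would fit the same picture. A single concentration also leaves open how compound 3 and compound 4 compare in potency.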